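The compounds below may be only part of what the source reports. "The series", "measured", "known", "first", "only" and "open" are said of these compounds alone.

Working notes on the series. The reference point is compound 1 `CCN(CC)CCNC(=O)c1ccc(C(CC)(CC)c2ccc(OCC(O)C(C)(C)C)c(C)c2)n1CC`, which in an assay on cells for agonist activity at vitamin D3 receptor (Homo sapiens), read by microscopy (on this read-out lower numbers stand for an effect already at smaller amounts and higher numbers for an effect only at larger amounts of compound), gives 6.54 nM. Compound 2 `CCn1c(C(=O)NCc2ccc(OC)cc2)ccc1C(CC)(CC)c1ccc(C#CC(O)(CC)CC)c(C)c1` gives in this assay only a limit, > 50 nM. Compound 3 `C#CCCOC(=O)c1ccc(C(CC)(CC)c2ccc(C#CC(O)(CC)CC)c(C)c2)n1CC` likewise gives in this assay only a limit, > 50 nM. Among the measured compounds shown here, the one single-point change among the measured compounds, a step that the two limits leave unreadable from compound 2 to compound 3, therefore cannot be sized; both ends sit at the limit, as noted in the limit of > 50 nM in this assay, at which 2 of the 3 values shown sit. Where compound 3 stands is thus known only as a limit, with no number behind it.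

The next compound, compound 4 `CCCCC(=O)c1ccc(C(CC)(CC)c2ccc(C#CC(O)(CC)CC)c(C)c2)n1CC`, differs from compound 3 in one place: butyl in place of (but-3-yn-1-yl)oxy on a carbonyl carbon. No measured step speaks to this change, since the only step shown, from compound 2 to compound 3, is unreadable, and compound 1 carries a different group at the carbonyl carbon altogether. No direction can be drawn for this assay from what is shown. The expectation for compound 4 is therefore set close to where compound 3 stands, at 120 nM with a range from 30 nM to 600 nM, with a fair chance that only a limit is reported again. The expected step that the limit leaves unreadable from compound 3 to compound 4 is accordingly taken as no clear change beyond the scatter.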

Compound 4, half-maximal effective concentration: > 50 nM
Compound 4 ended at the assay's limit (the forecaster's own chance of this, stated with the estimate: 65%); the middle value is on the limit's open side.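

In this assay compound 4 gives only a limit, > 50 nM. Its steps from compound 2 and compound 3 therefore cannot be read, as both ends of each are limits: the limit of > 50 nM in this assay, at which 3 of the 4 values shown sit.

Left open is where compound 2, compound 3 and compound 4 actually stand, and whether the group on the carbonyl carbon matters among them.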